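Dropping One Methoxy: From Compound 3 to Compound 4

The source may report more compounds than this note shows. Statements on the series, on what has been measured and on what is new or still open speak of the compounds shown alone.

Compound 1 `O=C(/C=C/c1ccc(O)cc1)c1ccc2occc2c1O` gives 10900 nM in an assay on isolated protein for inhibition of lysosomal alpha-glucosidase (Rattus norvegicus), read by spectrophotometry, with a stated time of 5 min; a lower number here means a stronger inhibitor, a higher number a weaker inhibitor.
Compound 2 `O=C(/C=C/c1ccc(O)c(O)c1)c1ccc2occc2c1O` gives 15200 nM in this assay.
Compound 3 `COc1cc(OC)c(OC)cc1/C=C/C(=O)c1cc2ccoc2cc1O` gives 13400 nM in this assay.

All three numbers lie close together; compound 3 differs from compound 2 and from compound 1 by less than the usual scatter of this assay. Compound 4 `COc1ccc(/C=C/C(=O)c2cc3ccoc3cc2O)cc1OC` differs from compound 3 in one place: hydrogen in place of methoxy on an aromatic carbon. Within the data shown here, no measured pair shows this same change. Among the measured compounds shown here, the only single-site step measured, a 1.4-fold higher number from compound 1 to compound 2 (0.14 log units; within the scatter), stays within the scatter, so a small change on an aromatic ring has so far moved this assay little. The expected step, a 1.0-fold lower number from compound 3 to compound 4 (0.01 log units; within the scatter), is therefore none beyond the scatter. Compound 4 is estimated at 13000 nM, with a range from 6000 nM to 28000 nM.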

Compound 4, half-maximal inhibitory concentration: 10800 nM
The estimate for compound 4 lay 1.2-fold (0.08 log units) above the measured number; measured number inside the range.
By their numbers in this assay, from the lowest: compounds 4, 1, 3 and 2 (each within the scatter of the next).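

At this position, ortho to a large group, a methoxy group can give way to hydrogen with no change beyond the scatter of this assay (a 1.2-fold lower number from compound 3 to compound 4 (0.09 log units; within the scatter)). Among these compounds, the earlier compounds did not test this position or this change, and the single step now adds a second small change on an aromatic ring that leaves the number within the scatter. Nothing at hand accounts for this result. Still open, as far as these compounds go, is whether a group of another kind here, such as an amine or a carboxylic acid, would move the number beyond the scatter.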